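A few compounds are considered here, and "the series" means these few. Any claim that something is new, unique, unknown or untested is made for them only; others in the source may bear on it.

Of the compounds shown here, two of a shared core have been measured so far. Compound 1 `COc1cc(-c2nn(-c3cccc(NC(=O)c4cccc(C(F)(F)F)c4)c3)cc2-c2ccncc2)ccc1Cl` gives 4010 nM in a functional assay on OVCAR-5 cells (Homo sapiens) for inhibition, read by sulforhodamine B assay, with a stated time of 48 h; a higher number here means a weaker inhibitor of growth, a lower number a stronger inhibitor of growth. Compound 2 `COc1cc(-c2nn(-c3cccc(NC(=O)c4ccc(Cl)c(C(F)(F)F)c4)c3)cc2-c2ccncc2)ccc1Cl` reaches only a limit of that assay in this assay, namely > 32500 nM. Within the data shown here, the single measured step, an at least 8.1-fold higher number from compound 1 to compound 2 (0.90 log units; beyond the scatter), is thus known only as a bound, because compound 2 sits at the limit of > 32500 nM in this assay, at which 1 of the 2 values shown sits. Where compound 2 truly stands beyond that limit the numbers do not tell.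

Compound 3 `COc1cc(-c2nn(-c3cccc(NC(=O)Nc4ccc(Cl)c(C(F)(F)F)c4)c3)cc2-c2ccncc2)ccc1Cl` has not been measured. It differs from compound 2 in one place: (4-chloro-3-(trifluoromethyl)phenyl)amino in place of 4-chloro-3-(trifluoromethyl)phenyl on a carbonyl carbon. Among the measured compounds shown here, no measured step covers a change of this kind; the one step available, an at least 8.1-fold higher number from compound 1 to compound 2 (0.90 log units; beyond the scatter), concerns a chloro group on a different ring and says nothing direct about the carbonyl side. The expectation for compound 3 therefore rests mainly on compound 2 standing at the limit, with wide uncertainty in either direction. Compound 3 is expected to give about 15000 nM in this assay, within a range of 3000 nM to 50000 nM. The step expected from compound 2 to compound 3 is an at least 2.1-fold lower number from compound 2 to compound 3 (0.33 log units; beyond the scatter).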

Compound 3, concentration for 50% growth inhibition: 3090 nM
The estimate for compound 3 lay 4.9-fold (0.69 log units) above the measured number; the range from low to high includes it.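

Setting (4-chloro-3-(trifluoromethyl)phenyl)amino in place of 4-chloro-3-(trifluoromethyl)phenyl on the carbonyl carbon brings the read-out in this assay back from the limit into the measurable range, giving an at least 10-fold lower number from compound 2 to compound 3 (1.02 log units; beyond the scatter), so this position, on which the earlier compounds offered no measured step, responds strongly to the change. Going by these compounds, the true size of this step remains unknown because it is known only as a bound: the limit of > 32500 nM in this assay, at which 1 of the 3 values shown sits. Although the chloro group is retained in the new compound, the loss that came with it on the amide does not reappear, with a 1.3-fold lower number from compound 1 to compound 3 (0.11 log units; within the scatter), so a chloro-bearing ring is compatible with measurable growth inhibition once the amino nitrogen is present.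

On these data alone, it remains open whether the amino nitrogen itself is what counts, or whether an oxygen atom or a methylene group on the carbonyl carbon in its place would serve as well. Also open, as far as these compounds go, is what (3-(trifluoromethyl)phenyl)amino without the chloro group would give on the carbonyl carbon, which would show whether the chloro group has any effect of its own in this setting.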